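A few compounds are considered here, and "the series" means these few. Any claim that something is new, unique, unknown or untested is made for them only; others in the source may bear on it.

Compound 1 `CC(C)CC(=O)c1c(O)c(C=O)c(O)c(C[C@@]2(C)CC[C@H]3C2=C[C@H](C(C)(C)O)CC[C@H]3C)c1O` and compound 2 `CC(C)C[C@H](c1c(O)c(C=O)c(O)c(C=O)c1O)[C@@]1(C)CC[C@H]2C1=C[C@H](C(C)(C)O)CC[C@H]2C` share the same core and were both tested in a functional assay on A549 cells (Homo sapiens) for cytotoxicity, read by sulforhodamine B assay, with a stated time of 72 h; a higher number here means a weaker inhibitor, a lower number a stronger inhibitor. In this assay compound 1 gives < 10000 nM, which is a limit of the assay rather than a number. In this assay compound 2 likewise gives < 10000 nM, again a limit and not a number. Compound 2 thus stands at the limit of < 10000 nM in this assay, at which 2 of the 2 values shown sit, so its place among the values shown cannot be fixed more closely than that. The move to compound 3 `CC(C)CC(c1c(O)c(C=O)c(O)c(C=O)c1O)[C@@]1(C)CC[C@H]2C1=C[C@H](C(C)(C)O)CC[C@H]2C` alters no atom and no bond: the two compounds have the same atoms and bonds; at least one stereo element is drawn with a configuration in one of them and without one in the other: 1 of 5 stereo elements differ; a stereocentre at a saturated chain carbon is drawn S in compound 2 and without a configuration in compound 3. Going by the values given here, no measured step between these compounds exists to lean on, and in this assay the step that the limit leaves unreadable from compound 2 to compound 3 is expected to be none beyond the scatter. Compound 3 is expected in this assay to give about 5000 nM, within a range from 1000 nM to 10000 nM, and will most likely again be reported only as a limit.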

Compound 3, half-maximal inhibitory concentration: < 10000 nM
Compound 3: a limit, no number; the forecaster's own chance of this, stated with the estimate: 75%; the middle value is on the limit's open side.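

Going by these compounds alone, compound 2 and compound 3 are both reported only as limits in this assay, so no step between them can be read: the limit of < 10000 nM in this assay, at which 3 of the 3 values shown sit.

The compounds shown leave open what their actual values are, and whether the configuration at the saturated chain carbon changes the value at all.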